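The compounds below may be only part of what the source reports. "The series", "measured", "known", "first", "only" and "open" are said of these compounds alone.

Measured so far:
- compound 1, `CC(O)(CSc1ccc(S(F)(F)(F)(F)F)cc1)C(=O)Nc1cccc(S(F)(F)(F)(F)F)c1`: 12700 nM
- compound 2, `CC(O)(CSc1ccc(F)cc1)C(=O)Nc1cccc(S(F)(F)(F)(F)F)c1`: 26900 nM
- compound 3, `CC(O)(CS(=O)(=O)c1ccc(S(F)(F)(F)(F)F)cc1)C(=O)Nc1cccc(S(F)(F)(F)(F)F)c1`: 11700 nM

All three were tested in a functional assay on LNCaP cells (Homo sapiens) for antiproliferative activity, read by propidium iodide staining, with a stated time of 96 h; on this read-out higher numbers stand for weaker inhibition and lower numbers for stronger inhibition. Compound 1 and compound 2 share a core and differ in one place: one fluorine atom in place of a group of 6 heavy atoms (5 fluorine, 1 sulfur; no ring), on an aromatic carbon. That change produced a 2.1-fold higher number from compound 1 to compound 2 (0.33 log units; beyond the scatter), so the smaller group in compound 2 went with a weaker result than the larger group in compound 1.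

Compound 3 has a different core from compound 1; how the two cores differ is not broken down here. In this assay compound 3 gives 11700 nM, which sits within the usual scatter of the number for compound 1, so no order between those two can be read from the data. Compound 2 lies beyond the scatter from compound 3, with the higher number.

Compound 4, `CC(O)(CS(=O)(=O)c1ccc(F)cc1)C(=O)Nc1cccc(S(F)(F)(F)(F)F)c1`, has not yet been measured. It relates to compound 3 as compound 2 relates to compound 1: one fluorine atom in place of a group of 6 heavy atoms (5 fluorine, 1 sulfur; no ring), on an aromatic carbon. The place of the change is described in the same words in both pairs, so this is the same change made on a second core.

On the core of compound 1 this change gave a 2.1-fold higher number from compound 1 to compound 2 (0.33 log units; beyond the scatter). Among the measured compounds shown here, with only that one step to rest on, the expectation is that on the core of compound 3 it acts alike, giving an estimated 2.1-fold higher number from compound 3 to compound 4 (0.33 log units; beyond the scatter). For compound 4 the expected result in this assay is therefore 25000 nM, with a plausible range from 12000 nM to 52000 nM.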

Compound 4, half-maximal inhibitory concentration: 32600 nM
For compound 4 the middle estimate is 1.3-fold (0.12 log units) below the measured one; the range from low to high includes it.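

In this assay, putting fluoro in place of the group of 6 heavy atoms on the aromatic carbon gave a 2.8-fold higher number from compound 3 to compound 4 (0.45 log units; beyond the scatter), in the same direction as the earlier 2.1-fold higher number from compound 1 to compound 2 (0.33 log units; beyond the scatter). Within the limits of these measurements, the size of the step did not depend on which of the two cores carried it: the same change on two cores in this assay, a 2.1-fold higher number (0.33 log units; beyond the scatter) from compound 1 to compound 2 and a 2.8-fold higher number (0.45 log units; beyond the scatter) from compound 3 to compound 4, 1.3-fold (0.12 log units) apart, within the scatter of two such steps This shows that the change carried over from the core of compound 1 to the core of compound 3 in this assay, but it rests on only two pairs and does not show that the step would stay the same on any further core, nor does it explain why the larger group goes with the lower numbers.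

The compounds shown leave open how other groups at this same place would compare, such as a chlorine atom, a trifluoromethyl, a nitrile or an amine, since only fluoro and the group of 6 heavy atoms appear there. They also leave open whether the step would hold on a core with a different link to this aromatic ring, such as a longer chain, or on one with a carboxylic acid in place of the hydroxyl group.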